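Swapping thiophene for benzofuran in a nucleoside series

This account rests on a few compounds, and the source may have more. Where it says the series, first, only, none or still open, it means among the compounds named here.

Three nucleoside analogues were tested in an ADME assay on BJ cells (Homo sapiens), read by MTT assay, with a stated time of 72 h; a higher number here means a weaker inhibitor, a lower number a stronger inhibitor. Compound 1, `Cc1nc(N)c2c(-c3cccs3)cn([C@@H]3O[C@H](CO)[C@@H](O)[C@H]3O)c2n1`, carries a thiophen-2-yl group on its shared core. In this assay compound 1 reaches only the limit of the assay, > 100000 nM, and not a number. Compound 2, `Cc1nc(N)c2c(-c3cc4ccccc4o3)cn([C@@H]3O[C@H](CO)[C@@H](O)[C@H]3O)c2n1`, differs from compound 1 by 1-benzofuran-2-yl in place of thiophen-2-yl on an aromatic carbon. Compound 2 also sits at a limit, > 100000 nM, in this assay. The step that the two limits leave unreadable from compound 1 to compound 2 therefore cannot be read, and this rests on (the limit of > 100000 nM in this assay, at which 3 of the 3 values shown sit). Compound 3, `CN(C)c1ncnc2c1c(-c1cccs1)cn2[C@@H]1O[C@H](CO)[C@@H](O)[C@H]1O`, has a different core; how the cores of compound 3 and compound 1 differ is not broken down here. Compound 3 gives a limit of > 100000 nM in this assay as well. Compound 4, `CN(C)c1ncnc2c1c(-c1cc3ccccc3o1)cn2[C@@H]1O[C@H](CO)[C@@H](O)[C@H]1O`, is not yet measured; it differs from compound 3 by 1-benzofuran-2-yl in place of thiophen-2-yl on an aromatic carbon, the same change that turns compound 1 into compound 2. Because the step that the two limits leave unreadable from compound 1 to compound 2 left both partners at the limit, compound 4 is expected to stay there too, with an estimated step that the limit leaves unreadable from compound 3 to compound 4. The expected value for compound 4 in this assay is 150000 nM, with a likely range from 50000 nM to 500000 nM, and most probably the assay will again report only a limit.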

Compound 4, half-maximal inhibitory concentration: > 100000 nM
Compound 4: a limit, no number; the forecaster's own chance of this, stated with the estimate: 85%; the middle value is on the limit's open side.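

Compound 4 also stops at a limit of the assay, so the swap from thiophen-2-yl to 1-benzofuran-2-yl cannot be read between compound 3 and compound 4, because neither has a number: the limit of > 100000 nM in this assay, at which 4 of the 4 values shown sit.

The compounds shown leave open whether this swap changes anything on either core, and which structures, if any, would give an actual number in this assay.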